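The source may report more compounds than this note shows. Statements on the series, on what has been measured and on what is new or still open speak of the compounds shown alone.

Working notes on the series. In an assay on CHO cells for positive allosteric modulation of metabotropic glutamate receptor 5 (Homo sapiens), read by FLIPR (on this read-out higher numbers stand for an effect only at larger amounts of compound and lower numbers for an effect already at smaller amounts), compound 1 `COc1cccc(C(=O)Nc2ccc(Cl)cc2CN2C(=O)c3ccccc3C2=O)c1` gives 1500 nM, the higher of the two numbers recorded. Compound 3 `CCOc1cccc2c1C(=O)N(Cc1cc(Cl)ccc1NC(=O)c1ccccn1)C2=O`, which carries a different core, sits at 280 nM in this assay, a gap beyond the scatter. Compound 2 `Cc1ccc2c(c1C)C(=O)N(Cc1cc(Br)ccc1NC(=O)c1ccccn1)C2=O` reaches only a limit in this assay, > 100000 nM, and gives no number; it is the one case of the limit of > 100000 nM in this assay, at which 1 of the 3 values shown sits. Among the compounds with values here, no pair measured so far differs in one place, so no measured step is at hand. Compound 4 `O=C(Nc1ccc(Cl)cc1CN1C(=O)c2ccccc2C1=O)c1ccccc1C(F)(F)F` keeps the core of compound 1 and shows (2-(trifluoromethyl)phenyl in place of 3-methoxyphenyl on a carbonyl carbon). Within the data shown here, with no comparable step to lean on, a change no larger than the scatter is expected for compound 4, a 1.2-fold higher number from compound 1 to compound 4 (0.08 log units; within the scatter). Compound 4 is therefore estimated at 1800 nM in this assay, within 500 nM to 7000 nM.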

Compound 4, half-maximal effective concentration: 5700 nM
Compound 4: the middle estimate sits 3.2-fold (0.50 log units) below what was measured; measured number inside the range.
By their numbers in this assay, from the lowest: compound 3; then compound 1; then compound 4. At a limit, above all of these: compound 2.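

On the carbonyl carbon of the shared core, the aryl group is not freely exchangeable in this assay: 2-(trifluoromethyl)phenyl in place of 3-methoxyphenyl gives a 3.8-fold higher number from compound 1 to compound 4 (0.58 log units; beyond the scatter). This first measured step in the series is modest, yet it shows that this position responds to a change of group. Within the data shown here, nothing measured so far accounts for the step. The compounds shown leave open whether the step follows from the loss of methoxy or the arrival of trifluoromethyl. Going by these compounds, how a nitrile or an amine on this phenyl ring would read in this assay also remains open.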